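Thiazolyl ketone sulfides: methoxy for chloro on the aryl ring

This account rests on a few compounds, and the source may have more. Where it says the series, first, only, none or still open, it means among the compounds named here.

Measured so far:
compound 1 `COc1ccc(-c2nc(SCC(=O)c3sc(-c4ccccc4)nc3C)nc(N)c2C#N)cc1` — 33.8%
compound 2 `COc1ccc(-c2nc(C)c(C(=O)CSc3nc(N)c(C#N)c(-c4ccc(Cl)cc4)n3)s2)cc1` — 23.1%

In a functional assay on U-87MG ATCC cells for antiproliferative activity against U-87 MG (Homo sapiens), read by MTT assay, with a stated time of 48 h, tested at 50 uM (a higher number here means a weaker effect of the compound at the concentration tested, a lower number a stronger effect), compound 2 gives 23.1%, the lowest of the two numbers; compound 1 gives 33.8%, a value higher by more than the scatter. Going by the values given here, no single-change step between the two is available, since compound 1 also differs elsewhere on the shared core.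

Compound 3 `COc1ccc(-c2nc(C)c(C(=O)CSc3nc(N)c(C#N)c(-c4ccc(OC)cc4)n3)s2)cc1` is not yet measured. It differs from compound 2 by methoxy in place of chloro on an aromatic carbon. Among the compounds with values here, with compound 1 as the only carrier of the methoxy group and no step to compare, the step is expected to be small, towards a higher number, and is estimated as a number 6.9 percentage points higher from compound 2 to compound 3 (within the scatter). For compound 3 the value expected is 30%, between 15% and 45%.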

Compound 3, a percentage reported as activity, at one concentration (the size of the read-out at that concentration, not a potency): 13%
For compound 3 the middle estimate is 17 percentage points above the measured one; the measured number lies below the stated range.
By their numbers in this assay, from the lowest: compound 3; then compound 2; then compound 1.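

Read in this assay, the 4-chlorophenyl to 4-methoxyphenyl change gives a lower number (a number 10.1 percentage points lower from compound 2 to compound 3 (beyond the scatter)), so methoxy at this position goes with a stronger effect at the concentration tested than chloro. Methoxy in place of hydrogen on an aromatic carbon also gives a lower number (a number 20.8 percentage points lower from compound 1 to compound 3 (beyond the scatter)), and both steps lie beyond the scatter. Nothing available explains either step.

Going by these compounds, whether an amine or a longer chain such as ethoxy at the same position would lower the number further remains open. So does the effect of compound 3 at any other concentration, since only a single concentration is shown.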